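The source may hold more compounds than are shown below. What is called first, only, known or untested is meant among the compounds shown, and "the series" means these compounds.

Measured compounds:
- compound 1, `CCCc1cc(N)c2cc(NC(=O)/C=C/c3ccc(C(C)(C)C)cc3)ccc2n1`: 22 nM
- compound 2, `CCCc1cc(N2CCCC2)c2cc(NC(=O)/C=C/c3ccc(C(F)(F)F)cc3)ccc2n1`: 17 nM

Both compounds were tested in an assay on isolated protein for displacement of a labelled ligand from melanin-concentrating hormone receptor 1 (Homo sapiens); a lower number here means a stronger inhibitor, a higher number a weaker inhibitor. Compound 1 gives 22 nM and compound 2 gives 17 nM. Compound 2 has the lower of the two numbers, but the gap to compound 1 lies within the usual scatter of repeated measurements, so the two cannot be told apart on this evidence. Compound 1 and compound 2 also differ at more than one place, so no single step can be read from them.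

Compound 3, `CCCc1cc(NC)c2cc(NC(=O)/C=C/c3ccc(C(F)(F)F)cc3)ccc2n1`, differs from compound 2 in exactly one place: methylamino in place of pyrrolidin-1-yl on an aromatic carbon. The group that leaves carries no hydrogen-bond donor, the group that enters carries one, and compound 1, which bears a plain amino group at the same carbon, gives a number that matches compound 2 within the scatter. Going by the values given here, nothing measured so far therefore points to a shift in either direction in this assay, and the expected step from compound 2 to compound 3 is a 1.2-fold higher number from compound 2 to compound 3 (0.07 log units; within the scatter), which is no step beyond the scatter. Compound 3 is thus expected to give about 20 nM, with a likely range from 8 nM to 50 nM.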

Compound 3, half-maximal inhibitory concentration: 1.5 nM
For compound 3 the middle estimate is 13-fold (1.12 log units) above the measured one, and the stated range ends above it.
By their numbers in this assay, from the lowest: compound 3; then compounds 2 and 1 (each within the scatter of the next).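

In this assay, going by these compounds alone, putting methylamino in place of pyrrolidin-1-yl on this aromatic carbon, opposite the ring nitrogen, gives an 11-fold lower number from compound 2 to compound 3 (1.05 log units; beyond the scatter), the first step that can be read at a single place. It shows that the group on this carbon matters to the number, which the two earlier compounds could not show, as they differ at more than one place and lie within the scatter of each other. This one change removes a ring, reduces the heavy atoms and adds a hydrogen-bond donor all at once, so the step cannot tell which of these counts, and no measurement is at hand that explains it.

As far as these compounds go, how dimethylamino, which has no ring, or ethylamino, a longer chain on the same nitrogen, would behave at this carbon stays open, and such groups could help separate the loss of the ring from the gain of the donor. Also open, from the compounds shown here alone, is whether the step would keep its size in a compound carrying the tert-butyl group of compound 1 in place of trifluoromethyl.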